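The source may report more compounds than this note shows. Statements on the series, on what has been measured and on what is new or still open speak of the compounds shown alone.

The account follows two measured compounds in a functional assay on the whole organism (stomach) with Rattus norvegicus as the target (on this read-out higher numbers stand for an effect only at larger amounts of compound and lower numbers for an effect already at smaller amounts), and one compound still to be tested. Compound 1, `CC/N=C(/NC#N)NCCCCn1nc(-c2ccccc2)ccc1=O`, gives 92 mg/kg in this assay. Compound 2, `CC/N=C(\S)NCCCn1nc(-c2ccccc2)ccc1=O`, reaches only a limit of the assay, reported as > 100 mg/kg. As far as these compounds go, that figure is not a number but (the limit of > 100 mg/kg in this assay, at which 1 of the 2 values shown sits), so compound 2 stands at the edge of what this assay can resolve, and whether it sits just past that edge or far beyond it remains open. Compound 1 and compound 2 differ in more than one place, so their two values show only that one lies at a number and the other at a limit.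

Compound 3, `C=CCNC(=S)NCCCCn1nc(-c2ccccc2)ccc1=O`, has not yet been measured. Compared with compound 2 it carries a group of 8 heavy atoms (5 carbon, 2 nitrogen, 1 sulfur; no ring) in place of a group of 6 heavy atoms (3 carbon, 2 nitrogen, 1 sulfur; no ring), on a saturated chain carbon, three bonds along the chain from an aromatic nitrogen. For the measured compounds named here, no measured pair shows a change of this kind, so the size of the step rests on expectation alone. The step that the limit leaves unreadable from compound 2 to compound 3 is expected to be small, not beyond the scatter, with no direction the data would support. Compound 3 is therefore estimated at 120 mg/kg in this assay, within a range from 50 mg/kg to 300 mg/kg, and the result may again come back only as a limit.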

Compound 3, dose for half-maximal effect: > 100 mg/kg
Compound 3 gave a limit, no number; the forecaster's own chance of this, stated with the estimate: 55%; the middle value does not contradict the limit.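

In this assay compound 3 gives > 100 mg/kg as a limit of the assay, not a number. Compound 2 also stands at a limit, so the change of a group of 6 heavy atoms for a group of 8 heavy atoms, on a saturated chain carbon, three bonds along the chain from an aromatic nitrogen, cannot be read, since both ends of that step lie at the same edge: the limit of > 100 mg/kg in this assay, at which 2 of the 3 values shown sit. For the compounds shown here, the change on an amine nitrogen is the first single-place comparison with a number at one end, and it gives an at least 1.0-fold higher number from compound 1 to compound 3 (0.03 log units; that floor lies within the scatter) as a floor only, so it shows no change beyond the scatter and does not fix the true size of the step.

As far as these compounds go, how far compound 2 and compound 3 lie past the limit remains open. Also open, from the compounds shown here alone, is whether a carboxylic acid or a benzyl group on the amine nitrogen would bring a number within the range of this assay.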